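The source may hold more compounds than are shown below. What is called first, only, known or untested is meant among the compounds shown, and "the series" means these compounds.

Measured compounds:
- Compound 1 `C[C@@H]1O[C@H](N2C(=O)/C(=C3\Nc4ccccc4C3=O)c3ccccc32)[C@H](O)[C@H](O)[C@H]1O`: in a functional assay on KYSE-70 cells (Homo sapiens) for antiproliferative activity, read by crystal violet staining, with a stated time of 96 h (on this read-out lower numbers stand for stronger inhibition and higher numbers for weaker inhibition), compound 1 gives only a limit, > 12500 nM.
- Compound 2 `O=C1/C(=C2/C(=O)N([C@@H]3O[C@H](CO)[C@H](O)[C@H](O)[C@H]3O)c3ccccc32)Nc2ccccc21`: in this assay compound 2 gives 41500 nM.
- Compound 3 `C[C@@H]1O[C@H](N2C(=O)/C(=C3\Nc4ccc(Cl)cc4C3=O)c3ccccc32)[C@H](O)[C@H](O)[C@H]1O`: in this assay compound 3 gives 5940 nM.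

Compound 2 stands at the highest of the two numbers reported; the nearest number, that of compound 3, is lower by a margin beyond the scatter, and the reading for compound 1 is a limit rather than a number. Among the measured compounds shown here, the only single-place step among the measured compounds is an at least 2.1-fold lower number from compound 1 to compound 3 (0.32 log units; beyond the scatter), and that step concerns a substituent change on an aromatic carbon, not the sugar part.

Compound 4 `O=C1/C(=C2/C(=O)N([C@@H]3O[C@H](CO)[C@@H](O)[C@H](O)[C@@H]3O)c3ccccc32)Nc2ccccc21` is the compound not yet measured. Its difference from compound 2 is the two compounds have the same atoms and bonds and differ only in configuration as drawn: 2 of 6 stereo elements differ; a stereocentre at a saturated ring carbon is drawn R in compound 2 and S in compound 4; a stereocentre at a saturated ring carbon is drawn R in compound 2 and S in compound 4. For the measured compounds named here, no measured step bears on a change of this kind, so the expectation rests on the common parts of compound 2 and compound 4 alone.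

The step from compound 2 to compound 4 is therefore expected to be a 1.0-fold lower number from compound 2 to compound 4 (0.02 log units; within the scatter), that is, no change beyond the scatter in either direction. Compound 4 is estimated to give 40000 nM in this assay, within a range from 10000 nM to 160000 nM.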

Compound 4, half-maximal inhibitory concentration: 11800 nM
Beside the measured number, compound 4's estimate is 3.4-fold (0.53 log units) above it, within the range that was stated.
By their numbers in this assay, from the lowest: compounds 3 and 4 (each within the scatter of the next); then compound 2.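

In this assay, among the compounds shown here, the earlier compounds offered a single-place step only at an aromatic carbon, and nothing on the sugar part. The new pair gives a 3.5-fold lower number from compound 2 to compound 4 (0.55 log units; beyond the scatter), the first sign that the number responds to the sugar part at all, with no atom or bond added or removed. The step can be assigned to the two saturated ring carbons drawn R in one compound and S in the other, because the rest of the structure is the same: the fact that compounds 2 and 4 differ only in the configuration as drawn

On these data alone, whether one of these two stereocentres alone accounts for the step remains open, as does whether it would carry over to the chloro-bearing core of compound 3. Also open, as far as these compounds go, is what an amine in place of the hydroxyl on either carbon would do to the number.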